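The compounds below may be only part of what the source reports. "The series", "measured", "known", "first", "only" and "open" are said of these compounds alone.

In a functional assay on HL-60 cells (Homo sapiens) for cytotoxicity, read by MTT assay, with a stated time of 72 h (on this read-out higher numbers stand for weaker inhibition and lower numbers for stronger inhibition), compound 1 `CC(C)(C)c1nc2ccccc2n1C(=O)c1cccc2ccccc12` gives 130 nM as its half-maximal inhibitory concentration, and compound 2 `COc1ccc(-c2nc3ccccc3n2C(=O)c2cccc3ccccc23)cc1` gives 146 nM on the same read-out. Within the data shown here, compound 2 thus stands level with compound 1, the only other number so far, and the two lie within the scatter of each other. Still unmeasured is compound 3 `O=C(c1cccc2ccccc12)n1c(C2CCC2)nc2ccccc21`, with cyclobutyl in place of 4-methoxyphenyl on an aromatic carbon, the difference being cyclobutyl in place of 4-methoxyphenyl on an aromatic carbon at that place. Among the measured compounds shown here, the single measured step bearing on this is a 1.1-fold higher number from compound 1 to compound 2 (0.05 log units; within the scatter) at the same place, so the exchange of tert-butyl for 4-methoxyphenyl moved nothing that can be read. For the measured compounds named here, with only that step to go on, no change beyond the scatter is expected for compound 3 in this assay on this evidence. The expected step is a 1.0-fold lower number from compound 2 to compound 3 (0.02 log units; within the scatter) in this estimate. Compound 3 is estimated at 140 nM with an expected range from 60 nM to 330 nM for this compound.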

Compound 3, half-maximal inhibitory concentration: 180 nM
Estimate against measurement, compound 3: 1.3-fold (0.11 log units) below, and the stated range covers the measured number.
By their numbers in this assay, from the lowest: compounds 1, 2 and 3 (each within the scatter of the next).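

In this assay, the aromatic carbon between two ring nitrogen atoms has now held three different groups with no readable shift: cyclobutyl in place of 4-methoxyphenyl gives a 1.2-fold higher number from compound 2 to compound 3 (0.09 log units; within the scatter), and cyclobutyl in place of tert-butyl gives a 1.4-fold higher number from compound 1 to compound 3 (0.14 log units; within the scatter). Compound 3 stands level with compound 2 even though cyclobutyl has a non-aromatic ring, 4 heavy atoms and 0 hydrogen-bond acceptors against the aromatic ring, 8 heavy atoms and 1 hydrogen-bond acceptor of 4-methoxyphenyl, so across these compounds neither the aromatic ring nor the methoxy oxygen is required at this place. No measurement at hand explains why the three stand level.

From the compounds shown here alone, all three groups at this place are uncharged, so it remains open whether an amine or a carboxylic acid there would move the number beyond the scatter. The compounds shown also share the rest of the core, which leaves the contribution of that part untested.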